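The source may report more compounds than this note shows. Statements on the series, on what has been measured and on what is new or still open speak of the compounds shown alone.

Going by the values given here, compound 2 `O=C(Nc1cccc(-c2oc3cc(-c4ccc(F)cc4)ccc3c(=O)c2O)c1)c1ccc(C(F)(F)F)cc1` gives 29400 nM in a functional assay on MDA-MB-231 cells (Homo sapiens) for antiproliferative activity, read by CCK-8 assay, with a stated time of 72 h (on this read-out lower numbers stand for stronger inhibition and higher numbers for weaker inhibition), the highest of the three numbers measured so far: compound 1 `O=C(Nc1cccc(-c2oc3cc(-c4ccc(F)cc4)ccc3c(=O)c2O)c1)c1ccc(Cl)cc1` gives 12800 nM and compound 3 `COc1cc(OC)cc(C(=O)Nc2cccc(-c3oc4cc(-c5ccc(F)cc5)ccc4c(=O)c3O)c2)c1` gives 4040 nM. Compound 4 `O=C(Nc1cccc(-c2oc3cc(-c4ccc(F)cc4)ccc3c(=O)c2O)c1)c1ccc(Cl)nc1` differs from compound 2 in one place: 6-chloropyridin-3-yl in place of 4-(trifluoromethyl)phenyl on a carbonyl carbon. The measured step that bears on this is a 2.3-fold higher number from compound 1 to compound 2 (0.36 log units; beyond the scatter), where chloro and trifluoromethyl on an aromatic carbon were compared directly; compound 4 carries a chloro again. Among the compounds with values here, no measured pair shows what the added ring nitrogen does. Reversing that step points to a modest move toward a lower number in this assay. Compound 4 is therefore expected to show a 2.5-fold lower number from compound 2 to compound 4 (0.39 log units; beyond the scatter). Compound 4 is estimated at 12000 nM, with a range from 5000 nM to 30000 nM.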

Compound 4, half-maximal inhibitory concentration: 1760 nM
Compound 4: middle estimate off by 6.8-fold (0.83 log units), on the high side, outside the stated range (below it).
By their numbers in this assay, from the lowest: compound 4; then compound 3; then compound 1; then compound 2.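

In this assay, going by these compounds alone, the group on this carbonyl carbon can shift the number far more than the earlier compounds showed, with 6-chloropyridin-3-yl giving a 17-fold lower number from compound 2 to compound 4 (1.22 log units; beyond the scatter), the only large step so far. The same group also gives a 2.3-fold lower number from compound 3 to compound 4 (0.36 log units; beyond the scatter) and a 7.3-fold lower number from compound 1 to compound 4 (0.86 log units; beyond the scatter), the last being a change in which a chloro remains and a ring nitrogen enters. Nothing measured here explains these gains. On these data alone, it remains open whether the gain depends on the chloro. A 6-aminopyridin-3-yl group, with an amine in its place, would test this.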